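Dimethylcarbamoyl to diethylcarbamoyl in compound 3

The source may hold more compounds than are shown below. What is called first, only, known or untested is meant among the compounds shown, and "the series" means these compounds.

- compound 1 `CNC(=N)Nc1nc(-c2ccc(OC)cc2)c(-c2ccc(OC)cc2)s1`: 1.2 uM
- compound 2 `COc1ccc(-c2nc(/N=C(\N)N3CCOCC3)sc2-c2ccc(OC)cc2)cc1`: 66 uM
- compound 3 `COc1ccc(-c2nc(C(=O)N(C)C)sc2-c2ccc(OC)cc2)cc1`: 3 uM

In a functional assay (aorta) with Rattus norvegicus as the target (a lower number here means that less compound is needed, a higher number that more compound is needed for the effect), compound 3 gives 3 uM, the middle of the three measured numbers. It sits close to one neighbour, a 2.5-fold higher number from compound 1 to compound 3 (0.40 log units; beyond the scatter), and far from the other, a 22-fold lower number from compound 2 to compound 3 (1.34 log units; beyond the scatter).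

Compound 4 `CCN(CC)C(=O)c1nc(-c2ccc(OC)cc2)c(-c2ccc(OC)cc2)s1` keeps the shared core and alters only the end of the carbonyl group: diethylamino in place of dimethylamino on a carbonyl carbon. In words, this is diethylamino in place of dimethylamino on a carbonyl carbon.

For the measured compounds named here, no measured step makes this exact change, so the evidence is indirect. All three measured steps replace the whole group on the aromatic carbon. The nearest guide is the move to the larger, ring-bearing group of compound 2, a 55-fold higher number from compound 1 to compound 2 (1.74 log units; beyond the scatter), which points toward higher numbers with more bulk. The change here is far smaller, and the data cannot show whether that trend carries over to it.

A small expected step, leaning upward and not clearly beyond the scatter, is a 1.7-fold higher number from compound 3 to compound 4 (0.22 log units; within the scatter). The estimated value for compound 4 is 5 uM, with an expected range from 1.5 uM to 20 uM.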

Compound 4, concentration for half-maximal effect: 14 uM
Compound 4: the middle estimate sits 2.8-fold (0.45 log units) below what was measured; low and high end bracket the measured number.
By their numbers in this assay, from the lowest: compound 1; then compound 3; then compound 4; then compound 2.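

Swapping dimethylamino for diethylamino on a carbonyl carbon changes the result in this assay (a 4.7-fold higher number from compound 3 to compound 4 (0.67 log units; beyond the scatter)), so even a change confined to the end of this group matters beyond the scatter. The other steps place this small edit in context: compound 4 still needs less compound than the compound with the ring-bearing group (a 4.7-fold lower number from compound 2 to compound 4 (0.67 log units; beyond the scatter)), but it clearly needs more than the compound with the open-chain nitrogen-rich group (a 12-fold higher number from compound 1 to compound 4 (1.07 log units; beyond the scatter)). Nothing shown gives a measured property that could account for the step from dimethylamino to diethylamino.

With only these two amides at this place, a single step cannot establish a trend with size. A longer chain such as dipropylamino, a ring amine such as pyrrolidine, or a smaller methylamino group on the same carbonyl carbon would show whether the number keeps rising.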